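This account rests on a few compounds, and the source may have more. Where it says the series, first, only, none or still open, it means among the compounds named here.

Two compounds share the same core and differ only in the group on a saturated chain carbon bound to an oxygen on an aromatic ring. Compound 1 `COc1cc(OC)c(-c2coc3cc(OCc4ccc(Br)cc4)ccc3c2=O)cc1OC` carries a 4-bromophenyl there, and in a functional assay on B16 cells (Mus musculus) for antiproliferative activity, read by MTT assay, with a stated time of 24 h (on this read-out higher numbers stand for weaker inhibition and lower numbers for stronger inhibition), compound 1 gives 1180 nM. Compound 2 `COc1cc(OC)c(-c2coc3cc(OCc4ccccc4C)ccc3c2=O)cc1OC` carries a 2-methylphenyl, and in this assay compound 2 gives 2150 nM. Compound 2 therefore has the higher of the two numbers, but the step of a 1.8-fold higher number from compound 1 to compound 2 (0.26 log units; within the scatter) is small. Compound 3 `COc1cc(OC)c(-c2coc3cc(OCc4cccc(Cl)c4)ccc3c2=O)cc1OC` has not been measured; it differs from compound 2 by 3-chlorophenyl in place of 2-methylphenyl on a saturated chain carbon bound to an oxygen on an aromatic ring. Among the measured compounds shown here, the only comparison that bears on this change is the step of a 1.8-fold higher number from compound 1 to compound 2 (0.26 log units; within the scatter), which shows that swapping one substituted phenyl for another at this position left the number within the scatter. No step beyond the scatter is therefore expected in this assay. Compound 3 is estimated at 1700 nM, with a range from 800 nM to 3800 nM, which means an expected step of a 1.3-fold lower number from compound 2 to compound 3 (0.10 log units; within the scatter).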

Compound 3, half-maximal inhibitory concentration: 2280 nM
For compound 3 the middle estimate is 1.3-fold (0.13 log units) below the measured one; low and high end bracket the measured number.
By their numbers in this assay, from the lowest: compounds 1, 2 and 3 (each within the scatter of the next).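

In this assay there is a 1.1-fold higher number from compound 2 to compound 3 (0.03 log units; within the scatter), so placing 3-chlorophenyl where compound 2 has 2-methylphenyl leaves the number within the scatter. Among the compounds shown here, there is also a 1.9-fold higher number from compound 1 to compound 3 (0.29 log units; within the scatter), which is again within the scatter, so the 4-bromophenyl, 2-methylphenyl and 3-chlorophenyl compounds can now all be read as alike at this position, where earlier only one swap of this kind could be judged. No outside evidence is available to explain this result.

As far as these compounds go, all three groups are substituted phenyl rings, so it remains open whether the number would hold with an amine, a carboxylic acid or a longer chain on that saturated chain carbon. From the compounds shown here alone, all three compounds also share one core, so these swaps remain untested on any other core.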